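Cyclohexyl to isobutyl on a shared core

The source may report more compounds than this note shows. Statements on the series, on what has been measured and on what is new or still open speak of the compounds shown alone.

Compound 1, `COc1cc(/C=C/C(=O)/C=C(/C=C/c2ccc(OC(C)=O)c(OC)c2)NC2CCCCC2)ccc1OC(C)=O`, gives > 25000 nM in a functional assay on HT-29 cells (Homo sapiens) for inhibition, read by MTT assay, with a stated time of 72 h (on this read-out higher numbers stand for weaker inhibition and lower numbers for stronger inhibition), a limit.
Compound 2, `COc1cc(/C=C/C(=O)/C=C(/C=C/c2ccc(OC(C)=O)c(OC)c2)NCC(C)C)ccc1OC(C)=O`, gives > 25000 nM in this assay, a limit.
Compound 3, `COc1cc(/C=C/C(=O)/C=C(/C=C/c2ccc(O)c(OC)c2)NC2CCCCC2)ccc1O`, gives > 25000 nM in this assay, a limit.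

None of the three values is a number; each is a limit of this assay, and (the limit of > 25000 nM in this assay, at which 3 of the 3 values shown sit). Compound 2 differs from compound 1 by isobutyl in place of cyclohexyl on an amine nitrogen, and the resulting step that the two limits leave unreadable from compound 1 to compound 2 cannot be read. The difference between the cores of compound 1 and compound 3 is not broken down here. Compound 4, `COc1cc(/C=C/C(=O)/C=C(/C=C/c2ccc(O)c(OC)c2)NCC(C)C)ccc1O`, has not yet been measured; it differs from compound 3 by isobutyl in place of cyclohexyl on an amine nitrogen, the same change as that from compound 1 to compound 2. Because (the limit of > 25000 nM in this assay, at which 3 of the 3 values shown sit), compound 4 is expected to sit at a limit as well. Compound 4 is estimated at 30000 nM, between 15000 nM and 80000 nM. The expected step is a step that the limit leaves unreadable from compound 3 to compound 4.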

Compound 4, half-maximal inhibitory concentration: 24500 nM
Compound 4: the middle estimate sits 1.2-fold (0.09 log units) above what was measured, and the stated range covers the measured number.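

In this assay the change from cyclohexyl to isobutyl on the amine nitrogen gives an at least 1.0-fold lower number from compound 3 to compound 4 (0.00 log units; that floor lies within the scatter), so no real difference between the two groups can be claimed on this core. This does not show that the change carries from one core to the other, since the same change on the core of compound 1 joins two limits and cannot be read, and the step on the core of compound 3 also starts from a limit, leaving its true size unknown. The data therefore offer no comparison between the two cores: the limit of > 25000 nM in this assay, at which 3 of the 4 values shown sit.

Still open, as far as these compounds go, is whether a benzyl group or a longer chain on the amine nitrogen would give a number clearly lower than this limit.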